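Adding hydroxyl groups to a side chain: compound 2 to compound 4

This account rests on a few compounds, and the source may have more. Where it says the series, first, only, none or still open, it means among the compounds named here.

compound 1 `COc1cc(C2CN(C(=O)c3cc(OCCO)ccn3)C2)ccc1OCc1ccc(C2CC2)cc1` gives 51%
compound 2 `COc1cc(C2CN(C(=O)c3cc(OC[C@H](O)CO)ccn3)C2)ccc1OCc1ccc(C2CC2)cc1` gives 67%
compound 3 `CCc1ccc(COc2ccc(C3CN(C(=O)c4cc(COCC(CO)(CO)CO)ccn4)C3)cc2OC)cc1` gives 58%

All three values come from an ADME assay on S9 fraction from liver (Rattus norvegicus, strain Sprague-Dawley) for metabolic stability, read by LC-MS, using NADPH, with stated times of 5 min and 60 min, tested at 5 uM; a higher number here means that more of the compound is left, a lower number that less of the compound is left. Compound 2 stands at 67%, within the usual scatter of compound 3 at 58%, so these two cannot be ranked. Only compound 1 lies clearly apart, with a number 16 percentage points higher from compound 1 to compound 2 (beyond the scatter).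

Compound 4 `COc1cc(C2CN(C(=O)c3cc(COCC(CO)(CO)CO)ccn3)C2)ccc1OCc1ccc(C2CC2)cc1` differs from compound 2 in one side chain: (3-hydroxy-2,2-bis(hydroxymethyl)propoxy)methyl in place of 2,3-dihydroxypropoxy on an aromatic carbon. Among the compounds with values here, no measured step isolates this exact change. The step of a number 16 percentage points higher from compound 1 to compound 2 (beyond the scatter) bears on it only loosely, as it also concerns a hydroxylated side chain at the same place. The closer guide is compound 3 at 58%, which already carries (3-hydroxy-2,2-bis(hydroxymethyl)propoxy)methyl but differs from compound 4 elsewhere in the molecule. On that evidence, a small fall that stays inside the scatter is expected. The estimated change is a number 7 percentage points lower from compound 2 to compound 4 (within the scatter). For compound 4 the estimated value is 60%, with an expected range of 46% to 74%.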

Compound 4, percent of the compound remaining: 73%
Compound 4: the middle estimate sits 13 percentage points below what was measured; low and high end bracket the measured number.
By their numbers in this assay, from the lowest: compounds 1, 3, 2 and 4 (each within the scatter of the next, the first and the last beyond it).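

Replacing 2,3-dihydroxypropoxy with the larger (3-hydroxy-2,2-bis(hydroxymethyl)propoxy)methyl, on the aromatic carbon opposite the ring nitrogen, gives no change that can be read in this assay (a number 6 percentage points higher from compound 2 to compound 4 (within the scatter)). The larger chain does stand clear of 2-hydroxyethoxy (a number 22 percentage points higher from compound 1 to compound 4 (beyond the scatter)), so this position tolerates a much bigger chain carrying more hydroxyl groups, and the two richest chains shown cannot be ranked against each other. The side chain is also not the only place that matters: with it held fixed, cyclopropyl in place of ethyl at the far end of the molecule gives a clear step (a number 15 percentage points higher from compound 3 to compound 4 (beyond the scatter)).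

On these data alone, whether an amine, a carboxylic acid or a longer chain would fare as well at this position stays open. Nothing shown here explains why any of these numbers differ.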